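Branching the acyl group on the amide of compound 2

The source may hold more compounds than are shown below. What is called first, only, known or untested is meant among the compounds shown, and "the series" means these compounds.

Three analogues sharing one core have been examined in a functional assay on HT-29 cells (Homo sapiens) for antiproliferative activity, read by MTT assay, with a stated time of 72 h, tested at 10 uM; a higher number here means more inhibition at the concentration tested (going by the name of the read-out), a lower number less inhibition. Compound 1 `CC(O)C(=O)Nc1cc(Oc2ccc(Nc3nccc4[nH]cc(-c5ccc(F)cc5)c(=O)c34)cc2F)ccn1` gives 47.8%. Compound 2 `CCC(=O)Nc1cc(Oc2ccc(Nc3nccc4[nH]cc(-c5ccc(F)cc5)c(=O)c34)cc2F)ccn1` gives 68.7%, the highest of the three numbers. Compound 3 `Nc1nccc(Oc2ccc(Nc3nccc4[nH]cc(-c5ccc(F)cc5)c(=O)c34)cc2F)c1Cl` gives 56.2%. The steps among them were a number 20.9 percentage points higher from compound 1 to compound 2 (beyond the scatter), a number 12.5 percentage points lower from compound 2 to compound 3 (beyond the scatter) and a number 8.4 percentage points higher from compound 1 to compound 3 (within the scatter).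

The next compound, compound 4 `CC(C)(C)C(=O)Nc1cc(Oc2ccc(Nc3nccc4[nH]cc(-c5ccc(F)cc5)c(=O)c34)cc2F)ccn1`, differs from compound 2 in one place: tert-butyl in place of ethyl on a carbonyl carbon. Going by the values given here, none of the measured steps touches the same place: the step from compound 1 to compound 2 concerns a hydroxy on the chain, and the step from compound 2 to compound 3 replaces the whole amide substituent. Both were modest, and they give no direct guide to lengthening the alkyl group on the carbonyl carbon. The expectation in this assay is therefore for no step beyond the scatter, estimated as a number 3.7 percentage points lower from compound 2 to compound 4 (within the scatter). Compound 4 is estimated at 65%, with a range from 45% to 80%.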

Compound 4, a percentage reported as inhibition, at one concentration (the size of the read-out at that concentration, not a potency): -45.8%
Compound 4: middle estimate off by 110.8 percentage points, on the high side; measured number outside the range, below it.
By their numbers in this assay, from the lowest: compound 4; then compounds 1 and 3 (each within the scatter of the next); then compound 2.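

The change from ethyl to tert-butyl on the carbonyl carbon comes with a number 114.5 percentage points lower from compound 2 to compound 4 (beyond the scatter), and tert-butyl in place of 1-hydroxyethyl comes with a number 93.6 percentage points lower from compound 1 to compound 4 (beyond the scatter), so in this assay this position, which had shown only a modest step with the loss of the hydroxy, now carries the largest steps in the set. Compound 4 alone gives a negative number, so here the change does more than lower the inhibition read at the concentration tested. Nothing shown here accounts for this result.

The compounds shown leave open whether isopropyl on the same carbonyl carbon would read closer to ethyl or to tert-butyl. They also leave open how a longer chain such as butyl, or an amine on the acyl group, would read.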